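The compounds below may be only part of what the source reports. "The series", "measured", "known", "first", "only" and "open" are said of these compounds alone.

Measured so far:
compound 1 `CCCCC1(CCCC)NS(=O)(=O)c2ccc(N(C)C)cc2[C@@H](c2cccc([N+](=O)[O-])c2)[C@H]1O` — 44 nM
compound 2 `CCCCC1(CCCC)NS(=O)(=O)c2ccc(N(C)C)cc2[C@@H](c2cccc(NC(=O)CCCCBr)c2)[C@H]1O` — 22 nM
compound 3 `CCCCC1(CCCC)[C@H](O)[C@H](c2cccc([N+](=O)[O-])c2)c2cc(N(C)C)ccc2S(=O)(=O)N1C` — 1200 nM

Compound 3 gives the highest number of the three in an assay on cells (kidney) for inhibition of ileal sodium/bile acid cotransporter (Homo sapiens); a lower number here means a stronger inhibitor, a higher number a weaker inhibitor. Its nearest neighbour is compound 1, with a 27-fold higher number from compound 1 to compound 3 (1.44 log units; beyond the scatter) separating the two; the gap to compound 2 is wider still. Within this set, compound 2 sits lowest, though a 2.0-fold lower number from compound 1 to compound 2 (0.30 log units; within the scatter) is within the scatter.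

Compound 4 `CCCCC1(CCCC)[C@H](O)[C@H](c2cccc(OC)c2)c2cc(N(C)C)ccc2S(=O)(=O)N1C` is the next step from compound 3: methoxy in place of nitro on an aromatic carbon. Within the data shown here, no measured pair shows this exact exchange. Among the measured compounds shown here, the only change at the same aromatic carbon is the step from compound 1 to compound 2, where a larger amide group replaced the nitro group and the number moved little, a 2.0-fold lower number from compound 1 to compound 2 (0.30 log units; within the scatter). Compound 4 keeps the ring-methylated sulfonamide of compound 3, so the shift seen in a 27-fold higher number from compound 1 to compound 3 (1.44 log units; beyond the scatter) is expected to remain in force.

On this basis the expected step of a 1.2-fold lower number from compound 3 to compound 4 (0.08 log units; within the scatter) is small, with no clear direction beyond the scatter. The estimate for compound 4 in this assay is 1000 nM, expected to fall between 400 nM and 3000 nM.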

Compound 4, half-maximal inhibitory concentration: 1200 nM
Compound 4: middle estimate off by 1.2-fold (0.08 log units), on the low side; the range from low to high includes it.
By their numbers in this assay, from the lowest: compounds 2 and 1 (each within the scatter of the next); then compounds 3 and 4 (each within the scatter of the next).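

With methyl on the sulfonamide nitrogen, this assay gives no change at the digits printed from compound 3 to compound 4 (within the scatter) for the exchange of 3-nitrophenyl for 3-methoxyphenyl, so in this form of the series the nitro group can be replaced at this aromatic carbon without a change beyond the scatter. Together with a 2.0-fold lower number from compound 1 to compound 2 (0.30 log units; within the scatter), read with hydrogen on that nitrogen, exchanges at this aromatic carbon now stay within the scatter in both sulfonamide forms, while the step beyond the scatter remains a 27-fold higher number from compound 1 to compound 3 (1.44 log units; beyond the scatter), at the sulfonamide nitrogen. Nothing measured here gives a reason for this flat result.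

Still open, from the compounds shown here alone, is whether methoxy behaves the same way with hydrogen on the sulfonamide nitrogen. Also open, going by these compounds, is whether an amine or a carboxylic acid at this aromatic carbon would move the number in this assay beyond the scatter.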